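The compounds below may be only part of what the source reports. "The series", "measured", "known", "first", "only" and "open" are said of these compounds alone.

In a functional assay on K562 cells (Homo sapiens) for inhibition, read by trypan blue exclusion, with a stated time of 72 h; a higher number here means a weaker inhibitor, a lower number a stronger inhibitor:
- compound 1 `COC(=O)Cn1c(=O)c(S(=O)(=O)c2ccc(F)cc2F)cc2cnc(Nc3ccc4[nH]ccc4c3)nc21`: 5000 nM
- compound 2 `Cn1c(=O)c(S(=O)(=O)c2ccc(F)cc2)cc2cnc(Nc3cnc4[nH]ccc4c3)nc21`: 750 nM

Compound 1 holds the higher of the two numbers, so it is the weaker inhibitor, and compound 2 lies lower by more than the scatter. Compound 3 `O=c1c(S(=O)(=O)c2ccc(F)cc2F)cc2cnc(Nc3ccc4[nH]ccc4c3)nc2n1C1CCCCC1` keeps the core of compound 1 and carries one change: cyclohexyl in place of (methoxycarbonyl)methyl on an aromatic nitrogen. Going by the values given here, no measured pair isolates this change, so the forecast is loose. A moderate move towards stronger inhibition is expected, which the estimated 3.3-fold lower number from compound 1 to compound 3 (0.52 log units; beyond the scatter) expresses. For compound 3 the estimate is 1500 nM, with an expected range of 300 nM to 7000 nM.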

Compound 3, half-maximal inhibitory concentration: 10000 nM
Estimate against measurement, compound 3: 6.7-fold (0.82 log units) below; the measured number lies above the stated range.
By their numbers in this assay, from the lowest: compound 2; then compounds 1 and 3 (each within the scatter of the next).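

In this assay, cyclohexyl in place of (methoxycarbonyl)methyl on the aromatic nitrogen gives a 2.0-fold higher number from compound 1 to compound 3 (0.30 log units; within the scatter) and so stays within the scatter. This position therefore carries an open chain with two hydrogen-bond acceptors or a carbon-only six-membered ring with none, without a difference that can be told apart in this assay. Nothing available bears on why the two groups read alike.

From the compounds shown here alone, whether an amine or a carboxylic acid on this nitrogen would also leave the number within the scatter stays open. So does whether a shorter or longer chain there would do so.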